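The source may report more compounds than this note shows. Statements on the series, on what has been measured and on what is new or still open speak of the compounds shown alone.

Measured so far:
- compound 1 `Cc1ccccc1/N=N/C(=N/NC(=O)c1cc(O)c(O)c(O)c1)c1ccccc1`: 41.5%
- compound 2 `O=C(N/N=C(/N=N/c1ccccc1Cl)c1ccccc1)c1cc(O)c(O)c(O)c1`: 32.7%

Going by the values given here, compound 1 stands highest of the two numbers in an ADME assay on RAW264.7 cells (Mus musculus) for inhibition, read by MTT assay, with a stated time of 72 h, tested at 100 uM (on this read-out lower numbers stand for less inhibition of growth and higher numbers for more inhibition of growth at the one concentration tested), though its only neighbour is compound 2, and the step of a number 8.8 percentage points lower from compound 1 to compound 2 (within the scatter) lies within the scatter, so no order between the two can be claimed.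

Compound 3 `O=C(N/N=C(/N=N/c1ccc(Cl)cc1Cl)c1ccccc1)c1cc(O)c(O)c(O)c1` is not yet measured in this assay. It differs from compound 1 in one place: 2,4-dichlorophenyl in place of 2-methylphenyl on a double-bonded nitrogen.

Among the compounds with values here, the single step that bears on this change is the one from compound 1 to compound 2, where chloro replaced methyl on the same aromatic carbon, giving a number 8.8 percentage points lower from compound 1 to compound 2 (within the scatter). Within the data shown here, compound 3 carries that chloro and a second one besides, and no other step in the set speaks to the second chlorine. The expected step is therefore small: a number 6.5 percentage points lower from compound 1 to compound 3 (within the scatter), in the direction of compound 2 but not beyond the scatter.

Compound 3 is estimated at 35% in this assay, with a range of 20% to 50%.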

Compound 3, percent growth inhibition at one concentration: 21.5%
Compound 3: the middle estimate sits 13.5 percentage points above what was measured; the measured number falls inside the stated range.
By their numbers in this assay, from the lowest: compound 3; then compounds 2 and 1 (each within the scatter of the next).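

In this assay, 2,4-dichlorophenyl in place of 2-methylphenyl on a double-bonded nitrogen gives a number 20 percentage points lower from compound 1 to compound 3 (beyond the scatter) and so moves the number by more than the scatter, which the exchange of methyl for chloro alone did not do in a number 8.8 percentage points lower from compound 1 to compound 2 (within the scatter) on the same aromatic carbon. Going by these compounds alone, the added second chlorine gives a number 11.2 percentage points lower from compound 2 to compound 3 (beyond the scatter), the first step that isolates this chlorine and reads beyond the scatter. Nothing measured here gives a reason for either step.

The aryl groups shown carry only methyl and chloro, so it remains open whether the lower number belongs to chloro specifically or would also follow from a methoxy group, an amine or a carboxylic acid on that aromatic carbon. On these data alone, with a single tested concentration, the shape of the concentration response for these compounds also remains open.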